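Bromo to iodo at the top of the tolerance range

The source may hold more compounds than are shown below. What is called first, only, known or untested is meant among the compounds shown, and "the series" means these compounds.

In an ADME assay on cells (Peritoneal macrophage, Mus musculus) for cytotoxicity, read by MTT assay, with a stated time of 24 h (a lower number here means that less compound is tolerated, a higher number that more compound is tolerated), compound 3 (`O=C(/N=C(/NCc1ccccc1)Nc1ccc(Br)cc1)c1ccccc1`) gives 738000 nM, the highest of three numbers. Compound 1 (`O=C(/N=C(/NCc1ccccc1)Nc1ccc(C(F)(F)F)cc1)c1ccccc1`) gives 18600 nM, and compound 2 (`O=C(/N=C(/NCc1ccccc1)Nc1ccccc1)c1ccccc1`) gives 35900 nM. Compound 4 (`O=C(/N=C(/NCc1ccccc1)Nc1ccc(I)cc1)c1ccccc1`) departs from compound 3 by a single change: iodo in place of bromo on an aromatic carbon. Among the compounds with values here, no measured step joins two halogens, so none speaks to this swap directly. The closest evidence is the pair of large steps that arrive at bromo, a 21-fold higher number from compound 2 to compound 3 (1.31 log units; beyond the scatter) and a 40-fold higher number from compound 1 to compound 3 (1.60 log units; beyond the scatter), while a 1.9-fold higher number from compound 1 to compound 2 (0.29 log units; within the scatter) stays within the scatter. The high number therefore rests on compound 3 alone, and the data do not show whether iodo shares it. A partial fall back is expected, smaller than either of those large steps. The expected step is a 3.7-fold lower number from compound 3 to compound 4 (0.57 log units; beyond the scatter). For compound 4 the estimated value is 200000 nM, with an expected range from 40000 nM to 800000 nM.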

Compound 4, half-maximal cytotoxic concentration: 619000 nM
The estimate for compound 4 lay 3.1-fold (0.49 log units) below the measured number; measured number inside the range.
By their numbers in this assay, from the lowest: compounds 1 and 2 (each within the scatter of the next); then compounds 4 and 3 (each within the scatter of the next).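

In this assay the high number proves not to be peculiar to bromo: a 1.2-fold lower number from compound 3 to compound 4 (0.08 log units; within the scatter) leaves iodo level with it at this place, on an aromatic carbon para to a large group. Iodo also keeps the large margins that bromo held, with a 17-fold higher number from compound 2 to compound 4 (1.24 log units; beyond the scatter) and a 33-fold higher number from compound 1 to compound 4 (1.52 log units; beyond the scatter) as the steps from hydrogen and from trifluoromethyl. Among these four compounds, bromo and iodo thus stand together at the high end, and hydrogen and trifluoromethyl together at the low end.

On these data alone, whether chloro or fluoro would join the high pair, or a methoxy group or an amine at this place would fall with the low pair, stays open. Nothing given here accounts for this division of the groups.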